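Swapping bromo for chloro on the sulfonamide aryl ring

The compounds below may be only part of what the source reports. "The series", "measured", "known", "first", "only" and "open" are said of these compounds alone.

Compound 1 `O=C1NCCN1c1ccc(S(=O)(=O)Nc2cccc(Br)c2)cc1`: 100 nM
Compound 2 `CCc1ccc(NS(=O)(=O)c2ccc(N3CCNC3=O)cc2)cc1`: 810 nM
Compound 3 `Cc1ccccc1NS(=O)(=O)c1ccc(N2CCNC2=O)cc1`: 280 nM

In a functional assay on MCF7 cells (Homo sapiens) for antiproliferative activity, read by sulforhodamine B assay, with a stated time of 48 h (on this read-out lower numbers stand for stronger inhibition and higher numbers for weaker inhibition), compound 1 gives the lowest of the three numbers. The next is compound 3, with a 2.8-fold higher number from compound 1 to compound 3 (0.45 log units; beyond the scatter), and the furthest is compound 2, with an 8.1-fold higher number from compound 1 to compound 2 (0.91 log units; beyond the scatter); between those two, a 2.9-fold lower number from compound 2 to compound 3 (0.46 log units; beyond the scatter). Compound 4 `O=C1NCCN1c1ccc(S(=O)(=O)Nc2cccc(Cl)c2)cc1` differs from compound 1 by chloro in place of bromo on an aromatic carbon. For the measured compounds named here, none of the measured steps exchanges one halogen for another; all three vary the whole aryl group on the sulfonamide nitrogen, and each moved the number only modestly. A like-for-like halogen exchange is expected to move it less still, so the step of a 1.5-fold higher number from compound 1 to compound 4 (0.18 log units; within the scatter) is expected to stay within the scatter, leaning slightly toward a higher number. For compound 4 the estimate in this assay is 150 nM, with a range from 60 nM to 400 nM.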

Compound 4, half-maximal inhibitory concentration: 79 nM
For compound 4 the middle estimate is 1.9-fold (0.28 log units) above the measured one; the range from low to high includes it.
By their numbers in this assay, from the lowest: compounds 4 and 1 (each within the scatter of the next); then compound 3; then compound 2.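

Exchanging bromo for chloro gives a 1.3-fold lower number from compound 1 to compound 4 (0.10 log units; within the scatter) in this assay and so leaves the two halogens indistinguishable at this place on the ring. The 3-chlorophenyl group keeps the lead over the other aryl groups that 3-bromophenyl held, with a 3.5-fold lower number from compound 3 to compound 4 (0.55 log units; beyond the scatter) and a 10-fold lower number from compound 2 to compound 4 (1.01 log units; beyond the scatter) as its margins. Nothing at hand accounts for the two halogens reading alike.

Open, as far as these compounds go, is whether this tolerance extends beyond chloro and bromo to fluoro, iodo, methoxy or an amine at this place. Also open, from the compounds shown here alone, is how 3-methylphenyl would compare with the two halogen compounds.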